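Hydrazone Thiazoles: From an Open Chain to a Thiophene

The source may hold more compounds than are shown below. What is called first, only, known or untested is meant among the compounds shown, and "the series" means these compounds.

Measured so far:
compound 1 `CCC(CC)=NNc1nc(-c2cccc(OC)c2)cs1`, 824 nM
compound 2 `COc1cccc(-c2csc(N/N=C/c3c[nH]c4ccccc34)n2)c1`, 414 nM

In an assay on isolated protein for inhibition of Amine oxidase [flavin-containing] A (Homo sapiens), read by fluorescence (on this read-out lower numbers stand for stronger inhibition and higher numbers for weaker inhibition), compound 1 gives 824 nM, and compound 2 gives 414 nM; the two numbers lie within the scatter of each other, so no order between them can be read. Compound 3 `COc1cccc(-c2csc(N/N=C/c3cccs3)n2)c1` is not yet measured. It differs from compound 1 as follows: a group of 7 heavy atoms (5 carbon, 1 nitrogen, 1 sulfur; one five-membered aromatic ring with 1 hetero atom) in place of a group of 6 heavy atoms (5 carbon, 1 nitrogen; no ring), on a nitrogen on an aromatic ring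

Within the data shown here, no measured step covers this change. Compound 2, which also carries a ring-bearing group at the same nitrogen, sits close to compound 1. The step of a 1.8-fold lower number from compound 1 to compound 3 (0.26 log units; within the scatter) is therefore expected to be modest, toward stronger inhibition. For compound 3 the estimate is 450 nM, with a range from 150 nM to 1400 nM.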

Compound 3, half-maximal inhibitory concentration: 458 nM
Estimate against measurement, compound 3: 1.0-fold (0.01 log units) below; the range from low to high includes it.
By their numbers in this assay, from the lowest: compounds 2, 3 and 1 (each within the scatter of the next).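

In this assay, a group with a five-membered aromatic ring with 1 hetero atom in place of the open chain, on a nitrogen on an aromatic ring, gives a 1.8-fold lower number from compound 1 to compound 3 (0.26 log units; within the scatter). The change from a group with no ring to this ring-bearing group therefore leaves the number at this position within the scatter. No available evidence accounts for this result. The compounds shown leave open whether a longer chain, an amine or a carboxylic acid on this nitrogen would give a step beyond the scatter.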